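This account rests on a few compounds, and the source may have more. Where it says the series, first, only, none or still open, it means among the compounds named here.

Measured in a functional assay on CWR22R cells (Homo sapiens) for antiproliferative activity, read by propidium iodide staining, with a stated time of 96 h; on this read-out lower numbers stand for stronger inhibition and higher numbers for weaker inhibition:

Compound 1 `CC(O)(CSc1ccc(F)cc1)C(=O)Nc1cccc(S(F)(F)(F)(F)F)c1` gives 30200 nM
Compound 2 `CC(O)(CSc1ccc(C(F)(F)F)cc1)C(=O)Nc1cccc(S(F)(F)(F)(F)F)c1` gives 26900 nM

Compound 2, at 26900 nM in this assay, stands level with compound 1 within the scatter, and only these two compounds have been measured. Compound 3 `CC(O)(CSc1cccc(C(F)(F)F)c1)C(=O)Nc1cccc(S(F)(F)(F)(F)F)c1` departs from compound 2 in one place: 3-(trifluoromethyl)phenyl in place of 4-(trifluoromethyl)phenyl on a sulfur with 3-(trifluoromethyl)phenyl in place of 4-(trifluoromethyl)phenyl on a sulfur. For the measured compounds named here, the one measured step, a 1.1-fold lower number from compound 1 to compound 2 (0.05 log units; within the scatter) for trifluoromethyl in place of fluoro on an aromatic carbon, stayed within the scatter. Going by the values given here, that step exchanges the group, whereas no measured step moves it, so the evidence is thin. No step beyond the scatter is expected in this assay in either direction. The expected change is a 1.1-fold lower number from compound 2 to compound 3 (0.03 log units; within the scatter) and nothing larger. The estimated value for compound 3 is 25000 nM within an expected range of 11000 nM to 50000 nM.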

Compound 3, half-maximal inhibitory concentration: 12900 nM
Compound 3: the middle estimate sits 1.9-fold (0.29 log units) above what was measured; the range from low to high includes it.
By their numbers in this assay, from the lowest: compound 3; then compounds 2 and 1 (each within the scatter of the next).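

In this assay, the position of the trifluoromethyl group on the aromatic ring carried by the sulfur matters: 3-(trifluoromethyl)phenyl in place of 4-(trifluoromethyl)phenyl gives a 2.1-fold lower number from compound 2 to compound 3 (0.32 log units; beyond the scatter). Compound 3 also stands apart from the fluoro compound, with a 2.3-fold lower number from compound 1 to compound 3 (0.37 log units; beyond the scatter), so its number is the lowest of the three, with both of its steps beyond the scatter, though both steps are modest. No measurement at hand accounts for this difference between the two placements of the group.

From the compounds shown here alone, it remains open whether the lower number is specific to 3-(trifluoromethyl)phenyl or would also appear with a nitrile, a chloro or a methoxy group on that ring. Also open, going by these compounds, is how a sulfonyl in place of the sulfur would behave alongside this group.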